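Amide Ring Swap on a Furanyl Aminopyrimidine Adenosine Ligand

The compounds below may be only part of what the source reports. "The series", "measured", "known", "first", "only" and "open" are said of these compounds alone.

Measured compounds:
Compound 1 `COc1cccc(-c2cc(-c3ccc(C)o3)nc(N)n2)c1`: 145 nM
Compound 2 `Cc1ccc(-c2cc(-c3cccc(C(=O)N4CCOCC4)c3)nc(N)n2)o1`: 52.1 nM

In an assay on membranes from brain (strain Sprague-Dawley) for displacement of a labelled ligand from adenosine receptor A1 (Rattus norvegicus), read by scintillation counting, with a stated time of 1 h (on this read-out lower numbers stand for stronger inhibition and higher numbers for weaker inhibition), compound 1 gives 145 nM and compound 2 gives 52.1 nM. Compound 2 stands lowest of the two numbers; the step of a 2.8-fold lower number from compound 1 to compound 2 (0.44 log units; beyond the scatter) came with (morpholin-4-yl)carbonyl in place of methoxy on an aromatic carbon. Compound 3 `Cc1ccc(-c2cc(-c3cccc(C(=O)N4CCCC4)c3)nc(N)n2)o1` differs from compound 2 by pyrrolidin-1-yl in place of morpholin-4-yl on a carbonyl carbon. Among the compounds with values here, no measured step bears directly on this change: the only step on hand exchanges the whole group on the aromatic carbon, not the ring on the carbonyl carbon, so it gives no direction for the present swap. Compound 3 is therefore expected to land close to compound 2, with a step of a 1.0-fold lower number from compound 2 to compound 3 (0.02 log units; within the scatter) in this assay, not beyond the scatter. The estimate for compound 3 is 50 nM, in the range 15 nM to 160 nM.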

Compound 3, inhibition constant: 36.8 nM
Compound 3: middle estimate off by 1.4-fold (0.13 log units), on the high side; the range from low to high includes it.
By their numbers in this assay, from the lowest: compounds 3 and 2 (each within the scatter of the next); then compound 1.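

In this assay the ring on the carbonyl carbon can be exchanged with only a 1.4-fold lower number from compound 2 to compound 3 (0.15 log units; within the scatter) as the result, so the ring oxygen of morpholin-4-yl, absent from pyrrolidin-1-yl, is not required to keep the number in this range. The step away from methoxy on the aromatic carbon now stands beyond the scatter for a second amide, with a 3.9-fold lower number from compound 1 to compound 3 (0.60 log units; beyond the scatter) for (pyrrolidin-1-yl)carbonyl, so this step is not confined to (morpholin-4-yl)carbonyl. No measurement at hand offers an explanation for either step.

The compounds shown leave open whether a larger piperidin-1-yl ring, a piperazin-1-yl ring with its free amine, or an open-chain dimethylamino group on the carbonyl carbon would stay in this range. They also leave open whether a carboxylic acid on the aromatic carbon could take the place of these amides.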